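This account rests on a few compounds, and the source may have more. Where it says the series, first, only, none or still open, it means among the compounds named here.

Of the compounds shown here, three sharing one core have been tested in an assay on CHO cells for displacement of a labelled ligand from adenosine receptor A1 (Homo sapiens), read by scintillation counting, with a stated time of 120 min, tested at 10 uM; on this read-out lower numbers stand for less inhibition and higher numbers for more inhibition at the one concentration tested (going by the name of the read-out). Compound 1 `Nc1scc(CN2CCN(c3ccc(Cl)cc3Cl)CC2)c1C(=O)c1ccc(Cl)cc1` gives 0% in this assay. Compound 2 `COc1ccc(N2CCN(Cc3csc(N)c3C(=O)c3ccc(Cl)cc3)CC2)cc1` gives 0%. Compound 3 `Nc1scc(CN2CCN(C3CCCCCC3)CC2)c1C(=O)c1ccc(Cl)cc1` gives 0%. The three differ only in the group on an amine nitrogen in a ring, and exchanging that group has so far made no difference: the step of no change at the digits printed from compound 1 to compound 2 (within the scatter) stays within the scatter, as does no change at the digits printed from compound 1 to compound 3 (within the scatter) and no change at the digits printed from compound 2 to compound 3 (within the scatter). Compound 3 therefore stands level with compound 1 and compound 2, with no inhibition shown at the concentration tested.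

Compound 4 `Nc1scc(CN2CCN(c3ccc(F)c(Cl)c3)CC2)c1C(=O)c1ccc(Cl)cc1` has not yet been measured. It differs from compound 3 by 3-chloro-4-fluorophenyl in place of cycloheptyl on an amine nitrogen in a ring. Every measured step that swaps this group, whether between two aromatic groups or between an aromatic group and a ring of carbon only, has stayed flat, so a further swap to an aromatic group is expected to stay flat as well. The step of no change at the digits printed from compound 3 to compound 4 (within the scatter) is expected to lie within the scatter. For compound 4 the estimated value in this assay is 0%, with a range from -8% to 10%.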

Compound 4, a percentage reported as inhibition, at one concentration (the size of the read-out at that concentration, not a potency): 0%
Estimate against measurement, compound 4: no gap at the digits printed; measured number inside the range.
By their numbers in this assay, from the lowest: compounds 1, 2, 3 and 4 (each within the scatter of the next).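

In this assay, putting 3-chloro-4-fluorophenyl in place of cycloheptyl on the amine nitrogen in a ring gives no change at the digits printed from compound 3 to compound 4 (within the scatter), and the swaps between aromatic groups read the same, with no change at the digits printed from compound 2 to compound 4 (within the scatter) and no change at the digits printed from compound 1 to compound 4 (within the scatter). This adds an aromatic ring carrying both fluorine and chlorine to the groups tried at this position, and it too leaves the reading where the other three stand, so none of the four gives any measurable inhibition at the one concentration tested. No supporting measurement is available to explain this flat result.

With all four compounds reading the same, they cannot be ranked, and they do not show whether any group at this position could bring out inhibition on this core. Still open, going by these compounds, is whether a benzyl group, a longer alkyl chain or a chain ending in a carboxylic acid on that nitrogen would behave differently, and whether replacing the 4-chlorophenyl on the carbonyl, which is the same in all four, would change the reading in this assay.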